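The source may report more compounds than this note shows. Statements on the series, on what has been measured and on what is new or still open speak of the compounds shown alone.

Working notes on a urea series tested in an ADME assay on HEK293 cells (Homo sapiens) for cytotoxicity, with a stated time of 72 h; a lower number here means that less compound is needed, a higher number that more compound is needed for the effect. Compound 1 `Cc1cc(NC(=O)Nc2cccc(Cl)c2)c2ccccc2n1` gives 21000 nM. Compound 2 `Cc1cc(NC(=O)Nc2cccc(C(F)(F)F)c2)c2ccccc2n1` gives 16000 nM, and compound 3 `COC(=O)c1cccc(NC(=O)Nc2cc(C)nc3ccccc23)c1` gives 26000 nM. Compound 3 thus carries the largest of the three numbers, yet every step leading to it stays within the scatter, so the three compounds cannot be told apart on these data. Within the data shown here, the single exchanges on the aromatic carbon are all small: a 1.3-fold lower number from compound 1 to compound 2 (0.12 log units; within the scatter); a 1.2-fold higher number from compound 1 to compound 3 (0.09 log units; within the scatter); a 1.6-fold higher number from compound 2 to compound 3 (0.21 log units; within the scatter).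

Compound 4 `Cc1cc(NC(=O)Nc2cccc(OC(F)(F)F)c2)c2ccccc2n1` continues this line of exchanges at the same aromatic carbon: trifluoromethoxy in place of methoxycarbonyl on an aromatic carbon. Among the measured compounds shown here, the steps that bear on it are the two already seen for methoxycarbonyl, namely a 1.2-fold higher number from compound 1 to compound 3 (0.09 log units; within the scatter) and a 1.6-fold higher number from compound 2 to compound 3 (0.21 log units; within the scatter), both within the scatter, and the earlier exchange a 1.3-fold lower number from compound 1 to compound 2 (0.12 log units; within the scatter) was no larger. Nothing in the measured compounds points to a step beyond the scatter for a fourth substituent on this carbon. The expected step is therefore a 1.3-fold lower number from compound 3 to compound 4 (0.11 log units; within the scatter), not beyond the scatter. Compound 4 is estimated at 20000 nM, with a range from 9000 nM to 45000 nM.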

Compound 4, half-maximal effective concentration: 22000 nM
Compound 4: the middle estimate sits 1.1-fold (0.04 log units) below what was measured; the measured number falls inside the stated range.
By their numbers in this assay, from the lowest: compounds 2, 1, 4 and 3 (each within the scatter of the next).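

In this assay, the exchange of methoxycarbonyl for trifluoromethoxy replaces a group holding a double bond outside the aromatic ring with one holding three fluorine atoms, yet the result is only a small step (a 1.2-fold lower number from compound 3 to compound 4 (0.07 log units; within the scatter)). The two other new comparisons at this aromatic carbon are also small (a 1.4-fold higher number from compound 2 to compound 4 (0.14 log units; within the scatter); a 1.0-fold higher number from compound 1 to compound 4 (0.02 log units; within the scatter)), so compounds 1, 2, 3 and 4 form one group that cannot be separated, and none of the four goes against this. No measurement bearing on why this position tolerates these exchanges is available for the series.

Still open, going by these compounds, is whether a carboxylic acid, an amine or a longer chain on this carbon would produce a step beyond the scatter. The compounds shown also leave open how far any change to the shared core would move the number, as all four carry it unchanged.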